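Shortening a Chain on an Aromatic Nitrogen: Compound 4

The source may report more compounds than this note shows. Statements on the series, on what has been measured and on what is new or still open speak of the compounds shown alone.

Compound 1 `COc1cccc(CNC(=O)c2c[nH]c3cc(-c4cn[nH]c4)ccc23)c1` gives < 1 nM in an assay on isolated protein for inhibition of Rho-associated protein kinase 2 (Homo sapiens) (a lower number here means a stronger inhibitor, a higher number a weaker inhibitor), a limit of the assay.
Compound 2 `COc1cccc(CNC(=O)c2cn(CCN(C)C)c3cc(-c4cn[nH]c4)ccc23)c1` gives < 1 nM in this assay, also a limit.
Compound 3 `COc1cccc(CN(C)C(=O)c2cc3ccc(-c4cn[nH]c4)nc3[nH]2)c1` gives 4 nM in this assay.

Compound 2 stands at the limit of < 1 nM in this assay, at which 2 of the 3 values shown sit, so only a limit is known for it, and the step that the two limits leave unreadable from compound 1 to compound 2 cannot be read in size or direction. Compound 3 has another core and is on the shown numbers close to that limit.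

Compound 4 `COc1cccc(CNC(=O)c2cn(C)c3cc(-c4cn[nH]c4)ccc23)c1` arises from compound 2 by hydrogen in place of (dimethylamino)methyl on a saturated chain carbon bound to an aromatic nitrogen. With both ends of this chain series at the limit, the expected step of a number no lower from compound 2 to compound 4 (the limit leaves the size open) is none beyond the scatter. Compound 4 is therefore estimated at 1 nM, within 0.3 nM to 3 nM.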

Compound 4, half-maximal inhibitory concentration: < 1 nM
Compound 4 gave a limit, no number; the forecaster's own chance of this, stated with the estimate: 55%; the middle value sits exactly at the limit.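

Compound 1, compound 2 and compound 4 all stand at the same limit of the assay, so no step among them can be read: the limit of < 1 nM in this assay, at which 3 of the 4 values shown sit.

As far as these compounds go, how far past that limit each of them lies in this assay, and so whether the chain on the aromatic nitrogen matters there, stays open.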